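Replacing the carbonyl substituent of compound 1 on the shared core

The source may hold more compounds than are shown below. What is called first, only, known or untested is meant among the compounds shown, and "the series" means these compounds.

Measured compounds:
compound 1 `COc1cc(-c2nn(-c3cccc(NC(=O)c4ccc(Cl)c(C(F)(F)F)c4)c3)cc2-c2ccncc2)ccc1Cl`: 6390 nM
compound 2 `O=C(Nc1cccc(-n2cc(-c3ccncc3)c(-c3ccc(Cl)c(O)c3)n2)c1)Nc1cc(C(F)(F)F)cc(C(F)(F)F)c1`: 1250 nM
compound 3 `COc1cc(-c2nn(-c3cccc(NC(=O)Nc4cccc(C(F)(F)F)c4)c3)cc2-c2ccncc2)ccc1Cl`: 1670 nM

In a functional assay on DU-145 cells (Homo sapiens) for inhibition, read by sulforhodamine B assay, with a stated time of 48 h (on this read-out lower numbers stand for stronger inhibition of growth and higher numbers for weaker inhibition of growth), compound 1 stands highest of the three numbers: compound 3 gives 1670 nM and compound 2 gives 1250 nM, both beyond the scatter below compound 1. Within the data shown here, only one measured step changes a single place: a 3.8-fold lower number from compound 1 to compound 3 (0.58 log units; beyond the scatter). Compound 2 differs from compound 1 in more than one place, so its value is taken only as a second point lying well under compound 1.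

Compound 4 `COc1cc(-c2nn(-c3cccc(NC(=O)Nc4ccc(Cl)c(Cl)c4)c3)cc2-c2ccncc2)ccc1Cl` is the next compound in the series. Relative to compound 1 it differs as follows: (3,4-dichlorophenyl)amino in place of 4-chloro-3-(trifluoromethyl)phenyl on a carbonyl carbon. This is the same kind of change at the same carbonyl carbon as the measured step from compound 1 to compound 3, which gave a modest, downward move beyond the scatter. On that basis a step of similar size and direction is expected for compound 4, a 3.6-fold lower number from compound 1 to compound 4 (0.55 log units; beyond the scatter), with compound 4 estimated at 1800 nM in this assay, within a range from 700 nM to 4500 nM.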

Compound 4, concentration for 50% growth inhibition: 1520 nM
Estimate against measurement, compound 4: 1.2-fold (0.07 log units) above; measured number inside the range.
By their numbers in this assay, from the lowest: compounds 2, 4 and 3 (each within the scatter of the next); then compound 1.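

In this assay, a second arylamino group on the carbonyl carbon also lowers the number, a 4.2-fold lower number from compound 1 to compound 4 (0.62 log units; beyond the scatter), so the drop is not confined to the (3-(trifluoromethyl)phenyl)amino group of compound 3. Exchanging 3-(trifluoromethyl)phenyl for 3,4-dichlorophenyl on the amide-type nitrogen leaves the two compounds indistinguishable, a 1.1-fold lower number from compound 3 to compound 4 (0.04 log units; within the scatter), so these two ring patterns cannot be told apart in this read-out. No measurement on these compounds accounts for either step.

From the compounds shown here alone, in both steps away from compound 1, the amide-type nitrogen enters together with a change in ring substituents, so the share of each remains open. Also open, going by these compounds, is how a carboxylic acid or a dimethylamino group on that phenyl ring would move the number.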